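Swapping Methyl for Cyclopropyl on the Oxazole Arm

The source may report more compounds than this note shows. Statements on the series, on what has been measured and on what is new or still open speak of the compounds shown alone.

Measured compounds:
Compound 1, `Cc1nnc(C2CC2)n1Cc1cc(C(F)(F)F)ccc1-c1cn(CC(=O)O)c2ccc(F)cc12`, gives 2 nM in an assay on isolated protein (blood) for antagonist activity at prostaglandin D2 receptor 2 (Homo sapiens), read by fluorescence, with a stated time of 10 min; a higher number here means a weaker inhibitor, a lower number a stronger inhibitor.
Compound 2, `Cc1ccn2c(CC(=O)O)cc(-c3ccc(C(F)(F)F)cc3Cc3c(C)noc3C3CC3)c2n1`, gives 26 nM in this assay.
Compound 3, `Cc1ccc2c(CC(=O)O)cn(-c3ccc(C(F)(F)F)cc3Cc3c(C)noc3C3CC3)c2n1`, gives 5 nM in this assay.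

Among these three numbers compound 3 stands second highest. Its nearest neighbour is compound 1, whose number is lower by a margin that lies beyond the usual scatter of repeated measurements. Its furthest neighbour is compound 2, whose number is higher, again by a margin beyond the scatter. None of these three compounds differs from another in only one place, so their values show where each one sits but not what any single structural change does.

Compound 4, `Cc1ccc2c(CC(=O)O)cn(-c3ccc(C(F)(F)F)cc3Cc3c(C4CC4)noc3C3CC3)c2n1`, is compound 3 with one change: cyclopropyl in place of methyl on an aromatic carbon. Going by the values given here, no measured pair in this set isolates such an exchange, so there is no direct precedent to lean on. The exchange is small and keeps the rest of the molecule intact, and the expectation is therefore a step of no change at the digits printed from compound 3 to compound 4 (within the scatter), with no clear direction and none beyond the scatter. The estimate for compound 4 in this assay is 5 nM, expected to fall between 2 nM and 15 nM.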

Compound 4, half-maximal inhibitory concentration: 60 nM
The estimate for compound 4 lay 12-fold (1.08 log units) below the measured number; measured number outside the range, above it.
By their numbers in this assay, from the lowest: compound 1; then compound 3; then compound 2; then compound 4.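

In this assay, replacing 5-cyclopropyl-3-methyl-1,2-oxazol-4-yl with 3,5-dicyclopropyl-1,2-oxazol-4-yl gives a 12-fold higher number from compound 3 to compound 4 (1.08 log units; beyond the scatter), a large step that shows this carbon, next to the ring nitrogen, is far from indifferent to the group it carries. The earlier compounds shown here differed from one another in more than one place and could show only where each one sat, whereas this pair isolates a single exchange, from the 1 heavy atom of methyl to the 3 heavy atoms of cyclopropyl, and the inhibitor becomes clearly weaker. No measurement in hand explains why this exchange weakens inhibition so much.

The compounds shown leave open whether the number rises gradually between methyl and cyclopropyl, which an ethyl or isopropyl group on the same carbon would test, and whether a plain hydrogen there would match methyl. They also leave open whether the same exchange would weaken inhibition to a similar extent on the core of compound 2, which carries the same 5-cyclopropyl-3-methyl-1,2-oxazol-4-yl group.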